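Swapping Chloro for Amino on the Fused Core

A few compounds are considered here, and "the series" means these few. Any claim that something is new, unique, unknown or untested is made for them only; others in the source may bear on it.

Compound 2 `Nc1nn(C(=O)Nc2ccc(Cc3ccccc3)cc2)c2ccc(Cl)cc12` gives 17400 nM in a functional assay on ACHN cells (Homo sapiens) for antiproliferative activity, read by sulforhodamine B assay, with a stated time of 48 h; on this read-out higher numbers stand for weaker inhibition of growth and lower numbers for stronger inhibition of growth. Its only measured companion, compound 1 `Nc1nn(C(=O)Nc2ccc(Cc3ccccc3)cc2)c2ccccc12`, gives 33400 nM; the step of a 1.9-fold lower number from compound 1 to compound 2 (0.28 log units; within the scatter) means the two values lie within the scatter of each other. Compound 3 `Nc1ccc2c(c1)c(N)nn2C(=O)Nc1ccc(Cc2ccccc2)cc1` differs from compound 2 by amino in place of chloro on an aromatic carbon. Among the compounds with values here, no measured step replaces chloro with amino; only the step from hydrogen to chloro at this position bears on it, and that step was small. A step of a 1.4-fold higher number from compound 2 to compound 3 (0.16 log units; within the scatter) is therefore expected, none beyond the scatter. Compound 3 is estimated at 25000 nM, ranging from 8000 nM to 80000 nM.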

Compound 3, concentration for total growth inhibition: 13700 nM
Compound 3: middle estimate off by 1.8-fold (0.26 log units), on the high side; the range from low to high includes it.
By their numbers in this assay, from the lowest: compounds 3, 2 and 1 (each within the scatter of the next, the first and the last beyond it).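

At this position on the shared core, amino and chloro cannot be told apart: the step of a 1.3-fold lower number from compound 2 to compound 3 (0.10 log units; within the scatter) is small, although amino brings a hydrogen-bond donor and acceptor that chloro lacks. Unlike chloro, amino does separate from hydrogen in this assay, with a 2.4-fold lower number from compound 1 to compound 3 (0.39 log units; beyond the scatter), though only modestly. Nothing available explains these numbers. On these data alone, whether a methoxy or a nitrile here would give a similar value remains open. So does whether amino would give the same modest step at another position on the core.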